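Haloacyl ureas: removing the methyl from compound 3

The source may hold more compounds than are shown below. What is called first, only, known or untested is meant among the compounds shown, and "the series" means these compounds.

Measured in a functional assay on CCRF-CEM cells (Homo sapiens) for antiproliferative activity, read by trypan blue exclusion, with a stated time of 72 h; on this read-out higher numbers stand for weaker inhibition and lower numbers for stronger inhibition:
- compound 1 `Cc1c(NC(=O)C(C)Cl)cccc1C(=O)NC(N)=O`: > 20000 nM (limit)
- compound 2 `COc1ccc(C(=O)NC(N)=O)cc1NC(=O)CCl`: > 20000 nM (limit)
- compound 3 `CC(Br)C(=O)Nc1cc(C(=O)NC(N)=O)cs1`: 3940 nM

Among the measured compounds shown here, compound 3, at 3940 nM, holds the only number in the set. Compound 1 and compound 2 report only limits, not numbers.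

Compound 4 `NC(=O)NC(=O)c1csc(NC(=O)CBr)c1` carries hydrogen in place of methyl on a saturated chain carbon bound to a bromine atom and a carbonyl carbon, so 1-bromoethyl becomes bromomethyl: hydrogen in place of methyl on a saturated chain carbon bound to a bromine atom and a carbonyl carbon.

For the measured compounds named here, no measured pair calibrates this change, so the expectation is only a modest step towards stronger inhibition in this assay. The expected step is a 2.0-fold lower number from compound 3 to compound 4 (0.29 log units; within the scatter). Compound 4 is estimated at 2000 nM, with an expected range of 400 nM to 9000 nM.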

Compound 4, half-maximal inhibitory concentration: 1130 nM
Compound 4: middle estimate off by 1.8-fold (0.25 log units), on the high side; the range from low to high includes it.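

In this assay, among the compounds shown here, bromomethyl in place of 1-bromoethyl gives a 3.5-fold lower number from compound 3 to compound 4 (0.54 log units; beyond the scatter), the only step that can be read. The methyl on this saturated chain carbon is therefore not needed for inhibition on this read-out, and removing it gives the lower number. The earlier compounds could not show this, because their results stop at a limit and not a number: the limit of > 20000 nM in this assay, at which 2 of the 4 values shown sit.

Still open, going by these compounds, is whether an ethyl group on this carbon would move the number the other way. Also open, on these data alone, is how chlorine in place of bromine would read on the core of compound 4.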